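A Phenylethenyl Group Replacing Cyclopropylethynyl on the Core

The source may report more compounds than this note shows. Statements on the series, on what has been measured and on what is new or still open speak of the compounds shown alone.

Measured so far:
Compound 1, `Nc1ncnn2c([C@@H]3O[C@H](CO)[C@@H](O)[C@H]3O)cc(C#CC3CC3)c12`: in a functional assay on LN-229 cells (Homo sapiens) for antiproliferative activity, with a stated time of 72 h (on this read-out higher numbers stand for weaker inhibition and lower numbers for stronger inhibition), compound 1 gives 30 nM.
Compound 2, `Nc1ncnn2c([C@@H]3O[C@H](CO)[C@@H](O)[C@H]3O)cc(C#Cc3ccccc3)c12`: compound 2 gives 88000 nM.
Compound 3, `Nc1ncnn2c([C@@H]3O[C@H](CO)[C@@H](O)[C@H]3O)cc(-c3ccccc3F)c12`: compound 3 gives > 100000 nM, which is a limit of the assay rather than a number.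

Compound 1 has the lowest of the two numbers available, and the third value is only a limit. Two steps lead away from it: a 2900-fold higher number from compound 1 to compound 2 (3.47 log units; beyond the scatter), and an at least 3300-fold higher number from compound 1 to compound 3 (3.52 log units; beyond the scatter). Between the two phenyl-bearing compounds, an at least 1.1-fold higher number from compound 2 to compound 3 (0.05 log units; that floor lies within the scatter). The limit for compound 3 is the limit of > 100000 nM in this assay, at which 1 of the 3 values shown sits.

Compound 4, `Nc1ncnn2c([C@@H]3O[C@H](CO)[C@@H](O)[C@H]3O)cc(/C=C/c3ccccc3)c12`, differs from compound 1 in one place: 2-phenylethenyl in place of 2-cyclopropylethynyl on an aromatic carbon. The bridge shrinks from a triple bond to a double bond, and a phenyl ring again replaces the small ring. Both measured exchanges that brought a phenyl ring onto this carbon gave large steps towards weaker inhibition. The double bond is not covered by any measured step, so the phenyl ring is the guide here. Compound 4 is therefore expected to show a large step towards weaker inhibition, a 1700-fold higher number from compound 1 to compound 4 (3.22 log units; beyond the scatter). The estimate for compound 4 is 50000 nM, with a range from 5000 nM to 300000 nM.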

Compound 4, half-maximal inhibitory concentration: 3900 nM
For compound 4 the middle estimate is 13-fold (1.11 log units) above the measured one; the whole stated range lies above it.
By their numbers in this assay, from the lowest: compound 1; then compound 4; then compound 2. At a limit, above all of these: compound 3.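

In this assay, a phenyl ring at this position does not by itself fix the outcome: with the ring kept and only its link to the core changed from a triple bond to a double bond, the step is a 23-fold lower number from compound 2 to compound 4 (1.35 log units; beyond the scatter). The double bond does not recover everything, as replacing 2-cyclopropylethynyl with 2-phenylethenyl still gives a 130-fold higher number from compound 1 to compound 4 (2.11 log units; beyond the scatter), so among these compounds the small ring on a triple bond remains clearly ahead. The phenyl ring held on a double bond also compares well with a directly attached 2-fluorophenyl group, with an at least 25-fold lower number from compound 3 to compound 4 (1.40 log units; beyond the scatter), although that step rests on a limit of the assay for compound 3 rather than a number: the limit of > 100000 nM in this assay, at which 1 of the 4 values shown sits.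

As far as these compounds go, what remains open is how a cyclopropyl ring would behave on a double bond, so the step from compound 1 cannot yet be divided between the change of bond and the change of ring. From the compounds shown here alone, it is also open how an amine or a longer hydrocarbon chain on the triple-bonded carbon would compare with the cyclopropyl group.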